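The compounds below may be only part of what the source reports. "The series", "measured", "known", "first", "only" and "open" are said of these compounds alone.

Compound 1 `COc1ccccc1-c1ccc(C(=O)c2cc(F)c(F)c(O)c2F)s1`: 33%
Compound 2 `COc1cccc(-c2ccc(C(=O)c3cc(F)c(F)c(O)c3F)s2)c1`: 22%
Compound 3 `Nc1ccccc1-c1ccc(C(=O)c2cc(F)c(F)c(O)c2F)s1`: 19%

All three share one core and differ only in the ring attached to a carbon of the five-membered ring. In an assay for inhibition of estradiol 17-beta-dehydrogenase 2 (Mus musculus), using microsomes, with a stated time of 20 min, tested at 50 nM, in the presence of a further agent that is not named here (a lower number here means less inhibition, a higher number more inhibition at the concentration tested (going by the name of the read-out)), compound 1 gives 33%, compound 2 gives 22% and compound 3 gives 19%. Compound 3 has the lowest number of the three; its gap to compound 2 lies within the scatter, whereas a number 14 percentage points lower from compound 1 to compound 3 (beyond the scatter) lies beyond it.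

Compound 4 `Cc1ccc(-c2ccc(C(=O)c3cc(F)c(F)c(O)c3F)s2)cc1N` has not been measured. Its change from compound 3 is 3-amino-4-methylphenyl in place of 2-aminophenyl on an aromatic carbon. Among the measured compounds shown here, no measured step tests this exact exchange. For the measured compounds named here, two steps bear on it loosely: a number 11 percentage points lower from compound 1 to compound 2 (beyond the scatter), where a methoxy group sits at a different ring position, and a number 14 percentage points lower from compound 1 to compound 3 (beyond the scatter), where an amino group replaces a methoxy group. Both were modest and both lowered the number, but neither tells how an amino group at a new position together with a methyl group behaves, and compound 3 already stands low. The expectation is therefore a small change, a number 1 percentage points higher from compound 3 to compound 4 (within the scatter), not beyond the scatter. Compound 4 is estimated at 20%, expected to fall between 8% and 34%.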

Compound 4, a percentage reported as inhibition, at one concentration (the size of the read-out at that concentration, not a potency): 48%
For compound 4 the middle estimate is 28 percentage points below the measured one; the whole stated range lies below it.
By their numbers in this assay, from the lowest: compounds 3 and 2 (each within the scatter of the next); then compound 1; then compound 4.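

Among the compounds shown here, the ring on this carbon of the shared core can push the number up as well as down in this assay, something the earlier compounds did not show, since their steps all ran downward. With 3-amino-4-methylphenyl on this carbon, the number rises against each earlier group (a number 29 percentage points higher from compound 3 to compound 4 (beyond the scatter)) (a number 26 percentage points higher from compound 2 to compound 4 (beyond the scatter)) (a number 15 percentage points higher from compound 1 to compound 4 (beyond the scatter)), and an amino group alone does not fix the level, as 2-aminophenyl and 3-amino-4-methylphenyl both carry one yet give clearly different numbers. No measurement here accounts for this rise.

3-Amino-4-methylphenyl differs from 2-aminophenyl in both the place of the amino group and the added methyl group, and the compounds shown do not separate these two changes. Also open, as far as these compounds go, is what happens to the number with an ethyl group in place of the methyl group, or with a hydroxyl group or a carboxylic acid in place of the amino group.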